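The compounds below may be only part of what the source reports. "The series", "measured", "known", "first", "only" and "open" are said of these compounds alone.

The measured compounds, all in a functional assay on PC-3 cells (Homo sapiens) for inhibition; a higher number here means a weaker inhibitor, a lower number a stronger inhibitor:
Compound 1, `Cc1c(C(=O)N/N=C\c2cc(O)ccc2O)oc2cccc(O)c12`, gives 95500 nM.
Compound 2, `Cc1c(C(=O)N/N=C\c2cccc(O)c2)oc2cccc(O)c12`, gives 17600 nM.
Compound 3, `Cc1c(C(=O)N/N=C\c2cccc(F)c2)oc2cccc(O)c12`, gives only a limit of the assay, >= 40000 nM.

Compound 3 therefore stands at the upper edge of what this assay can read; its result is a limit rather than a number, (the limit of >= 40000 nM in this assay, at which 1 of the 3 values shown sits), so its exact standing cannot be placed. Compound 4, `Cc1c(C(=O)N/N=C\c2c(O)cccc2F)oc2cccc(O)c12`, differs from compound 3 in one place: 2-fluoro-6-hydroxyphenyl in place of 3-fluorophenyl on a carbon with a double bond to nitrogen. Among the measured compounds shown here, two measured steps bear on this change. The step of an at least 2.2-fold higher number from compound 2 to compound 3 (0.35 log units; beyond the scatter) shows that fluoro in place of hydroxy gave a higher number, while a 5.4-fold lower number from compound 1 to compound 2 (0.73 log units; beyond the scatter) shows that taking away one hydroxy gave a lower number. Compound 4 keeps the fluoro and gains a hydroxy, so these two steps pull in opposite directions and neither fixes the size of the change. For compound 4 the expected step is a number no higher from compound 3 to compound 4 (the limit leaves the size open), small enough that this assay may again report only a limit. Compound 4 is estimated at about 40000 nM, within a range from 12000 nM to 120000 nM.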

Compound 4, half-maximal inhibitory concentration: 8050 nM
Estimate against measurement, compound 4: 5.0-fold (0.70 log units) above; measured number outside the range, below it.
By their numbers in this assay, from the lowest: compound 4; then compound 2; then compound 1.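

In this assay, the 2-fluoro-6-hydroxyphenyl group on this carbon turns a ring with fluoro alone into the best of the rings shown, with an at least 4.9-fold lower number from compound 3 to compound 4 (0.69 log units; beyond the scatter). It also outdoes both rings that carry only hydroxy groups, with a 2.2-fold lower number from compound 2 to compound 4 (0.34 log units; beyond the scatter) and with a 12-fold lower number from compound 1 to compound 4 (1.07 log units; beyond the scatter), so here fluoro and hydroxy together give a lower number than either kind of ring without the other group. The first of these steps gives only a minimum size, since compound 3 is reported only as a limit: the limit of >= 40000 nM in this assay, at which 1 of the 4 values shown sits.

The compounds shown do not separate the part played by the added hydroxy from the part played by the different place of the fluoro. As far as these compounds go, how a methoxy, a chloro or an amine would read in place of that hydroxy also stays open.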